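Methoxyphenyl Replaces Dichlorophenyl on the Carbonyl Side

This account rests on a few compounds, and the source may have more. Where it says the series, first, only, none or still open, it means among the compounds named here.

Compound 2 `COc1cc(-c2cc(/C=C/C(=O)c3ccc(Cl)c(Cl)c3)[nH]n2)cc(OC)c1OC` and compound 1 `COc1ccc(-c2cc(/C=C/C(=O)c3ccc(N)cc3)[nH]n2)cc1` were both tested in a functional assay on NCI-H522 cells (Homo sapiens) for cytotoxicity, read by sulforhodamine B assay, with a stated time of 48 h, tested at 0.01 uM; on this read-out higher numbers stand for a weaker effect at the one concentration tested and lower numbers for a stronger effect. In this assay compound 1 gives 84%, and compound 2 gives 92%. Compound 2 holds the highest of the two numbers, yet its nearest neighbour, compound 1, lies lower only by an amount within the scatter, so no order can be claimed between them; each shows only a weak effect at this single concentration.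

Compound 3 `COc1ccc(C(=O)/C=C/c2cc(-c3cc(OC)c(OC)c(OC)c3)n[nH]2)cc1` has not yet been measured in this assay. The change from compound 2 to compound 3 is 4-methoxyphenyl in place of 3,4-dichlorophenyl on a carbonyl carbon. No measured pair here differs in just one place, so the size of such a step has no direct precedent among these compounds. Because compound 1 with 84% and compound 2 with 92% both show weak effects despite different groups on the carbonyl carbon, the step is expected to stay within the scatter, with no clear direction. The estimated step is a number 3 percentage points lower from compound 2 to compound 3 (within the scatter). Compound 3 is therefore estimated at 89%, within a range from 78% to 100%.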

Compound 3, a percentage reported as activity, at one concentration (the size of the read-out at that concentration, not a potency): 83%
Compound 3: middle estimate off by 6 percentage points, on the high side, within the range that was stated.
By their numbers in this assay, from the lowest: compounds 3, 1 and 2 (each within the scatter of the next).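

Within the data shown here, replacing 3,4-dichlorophenyl with 4-methoxyphenyl on a carbonyl carbon gives the first comparison here in which only one place differs, and in this assay the step is a number 9 percentage points lower from compound 2 to compound 3 (within the scatter). At this position, then, a ring carrying two chlorine atoms and a ring carrying a methoxy group cannot be told apart at this single concentration, even though the two groups differ in their atoms and the methoxy group brings a hydrogen-bond acceptor that the dichlorophenyl group lacks. This one exchange leaves the effect weak, and nothing at hand explains why the two groups read alike.

A single low concentration cannot show whether the two groups would separate at higher concentrations, where a stronger effect might leave more room for a difference to appear. On these data alone, it also remains open whether a quite different group on the carbonyl carbon, such as a phenyl ring bearing a carboxylic acid or a longer alkoxy chain, would move the read-out beyond the scatter.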